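Replacing anilino with 4-nitrophenyl on a carbonyl carbon

The compounds below may be only part of what the source reports. "The series", "measured", "known", "first", "only" and "open" are said of these compounds alone.

Measured so far in a functional assay on HCT-15 cells (Homo sapiens) for antiproliferative activity, read by sulforhodamine B assay, with a stated time of 48 h (a higher number here means a weaker inhibitor, a lower number a stronger inhibitor), for two compounds
compound 1 `CC1=CC[C@H](C(C)C)c2cc(C)c(OC(=O)c3ccc(C)cc3)cc21` gives 40300 nM
compound 2 `CC1=CC[C@H](C(C)C)c2cc(C)c(OC(=O)Nc3ccccc3)cc21` gives 30 nM

Compound 2 holds the lower of the two numbers. Compound 3 `CC1=CC[C@H](C(C)C)c2cc(C)c(OC(=O)c3ccc([N+](=O)[O-])cc3)cc21` differs from it by 4-nitrophenyl in place of anilino on a carbonyl carbon. For the measured compounds named here, one measured step bears on this change, a 1300-fold lower number from compound 1 to compound 2 (3.13 log units; beyond the scatter) (anilino in place of 4-methylphenyl on a carbonyl carbon), and it is large and beyond the scatter. Compound 3 loses the anilino and, like compound 1 (40300 nM), carries a substituted phenyl on that carbonyl carbon, so a large step to a higher number is expected in this assay for this change. Going by the values given here, no measured compound carries 4-nitrophenyl, and one step is thin evidence, so the range stays wide. The expected step is a 670-fold higher number from compound 2 to compound 3 (2.82 log units; beyond the scatter) on this estimate. Compound 3 is expected at 20000 nM with an estimated range of 3000 nM to 80000 nM for the measurement.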

Compound 3, half-maximal inhibitory concentration: 56300 nM
Estimate against measurement, compound 3: 2.8-fold (0.45 log units) below; measured number inside the range.
By their numbers in this assay, from the lowest: compound 2; then compounds 1 and 3 (each within the scatter of the next).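

In this assay, a 1900-fold higher number from compound 2 to compound 3 (3.27 log units; beyond the scatter) with 4-nitrophenyl in place of anilino on the carbonyl carbon, so a second phenyl group at this position also lacks the low number of compound 2. With a 1.4-fold higher number from compound 1 to compound 3 (0.15 log units; within the scatter) for nitro in place of methyl on an aromatic carbon, the two substituents cannot be told apart here, and the ring substituent shows no sign of replacing what anilino provides. Among the three compounds, the low number occurs only with anilino, but no measured data on the compounds offer an explanation for this.

Going by these compounds, it remains open whether the result depends on the hydrogen on the anilino nitrogen or on the whole anilino group. A methylated anilino group, benzylamino or cyclohexylamino at the same carbonyl carbon would help separate these possibilities.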